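A few compounds are considered here, and "the series" means these few. Any claim that something is new, unique, unknown or untested is made for them only; others in the source may bear on it.

Compound 1 `CCOc1ccccc1-c1ccc(-c2nc3cnccc3c(NC(COC)C(N)=O)c2C#N)cc1`: 2.8
Compound 2 `CC[C@@H](Nc1c(C#N)c(-c2ccc(-c3ccccc3NC)cc2)nc2cnccc12)C(N)=O`: 2.5
Compound 3 `CN(CC(N)=O)c1c(C#N)c(-c2ccc(Br)cc2)nc2cnccc12`: 2.1

These three compounds were measured in a physicochemical assay for lipophilicity, read by HPLC, at pH 7.5; a higher number here means a more lipophilic compound, a lower number a more polar compound. Compound 2 holds the second highest of the three numbers. Its nearest neighbour is compound 1, whose value sits higher by an amount within the usual scatter, so the two cannot be told apart. Compound 3 lies furthest away, lower by an amount beyond the scatter.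

Compound 4 `CC[C@@H](Nc1c(C#N)c(-c2ccc(-c3cnccc3C)cc2)nc2cnccc12)C(N)=O` has not yet been measured. It differs from compound 2 in one place: 4-methylpyridin-3-yl in place of 2-(methylamino)phenyl on an aromatic carbon. Among the measured compounds shown here, no directly comparable step between measured compounds is available. In this assay this change is expected to lower the number by a moderate step, beyond the scatter. For compound 4 the expected value is 1.7, with a range from 1.2 to 2.3. Relative to compound 2, the expected step for compound 4 is a number 0.80 log units lower from compound 2 to compound 4 (beyond the scatter).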

Compound 4, distribution coefficient: 2
Beside the measured number, compound 4's estimate is 0.30 log units below it; the measured number falls inside the stated range.
By their numbers in this assay, from the lowest: compounds 4 and 3 (each within the scatter of the next); then compounds 2 and 1 (each within the scatter of the next).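

In this assay the swap of 2-(methylamino)phenyl for 4-methylpyridin-3-yl, on an aromatic carbon para to a large group, gives a number 0.50 log units lower from compound 2 to compound 4 (beyond the scatter) and is the first change in one place alone among these compounds. It shows that the number responds to this group with the rest of the molecule held constant. Nothing shown explains the step.

The swap changes the ring atoms and the substituent together, so their shares stay unresolved. A 2-methylphenyl or an unsubstituted pyridin-3-yl group here would separate them.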